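Urea series: moving the bromine on the outer ring

This account rests on a few compounds, and the source may have more. Where it says the series, first, only, none or still open, it means among the compounds named here.

Measured compounds:
compound 1 `COc1cc(NC(=O)Nc2cc(Nc3cccc(C(C)(C)C)c3)ncn2)cc(OC)c1`: 13.1%
compound 2 `CCc1cccc(Nc2cc(NC(=O)Nc3cc(OC)cc(OC)c3)ncn2)c1`: 23%
compound 3 `COc1cc(NC(=O)Nc2cc(Nc3ccc(Br)cc3OC)ncn2)cc(OC)c1`: 36.1%

In a functional assay on NCI-H520 cells (Homo sapiens) for inhibition, read by MTT assay, with a stated time of 48 h, tested at 10 uM (on this read-out lower numbers stand for less inhibition and higher numbers for more inhibition at the one concentration tested (going by the name of the read-out)), compound 3 gives 36.1%, the highest of the three numbers. The steps of a number 23 percentage points higher from compound 1 to compound 3 (beyond the scatter) and a number 13.1 percentage points higher from compound 2 to compound 3 (beyond the scatter) both lie beyond the scatter, whereas a number 9.9 percentage points higher from compound 1 to compound 2 (within the scatter) does not. Compound 4 `COc1cc(NC(=O)Nc2cc(Nc3cc(Br)ccc3OC)ncn2)cc(OC)c1` differs from compound 3 by 5-bromo-2-methoxyphenyl in place of 4-bromo-2-methoxyphenyl on a nitrogen on an aromatic ring. For the measured compounds named here, no measured step shifts a substituent within the same ring; the two steps into compound 3 each exchanged the whole group on the nitrogen and were only modest. There is therefore no basis for expecting a step beyond the scatter, and the expected step of a number 0.1 percentage points lower from compound 3 to compound 4 (within the scatter) is about none. Compound 4 is estimated at 36%, with a range from 18% to 54%.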

Compound 4, a percentage reported as inhibition, at one concentration (the size of the read-out at that concentration, not a potency): 43.5%
Beside the measured number, compound 4's estimate is 7.5 percentage points below it; the range from low to high includes it.
By their numbers in this assay, from the lowest: compounds 1 and 2 (each within the scatter of the next); then compounds 3 and 4 (each within the scatter of the next).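

In this assay, the first shift of a substituent within one ring, 5-bromo-2-methoxyphenyl in place of 4-bromo-2-methoxyphenyl, gives a number 7.4 percentage points higher from compound 3 to compound 4 (within the scatter) and so separates neither isomer from the other. The 5-bromo-2-methoxyphenyl group also stands clear of 3-ethylphenyl, with a number 20.5 percentage points higher from compound 2 to compound 4 (beyond the scatter) here, and of 3-(tert-butyl)phenyl, with a number 30.4 percentage points higher from compound 1 to compound 4 (beyond the scatter) as the largest step in the set. Nothing available explains these steps.

Going by these compounds, what a chlorine or a nitrile in place of the bromine would give remains open. For the compounds shown here, the separate contribution of the methoxy group on this ring also remains open, as no pair here isolates it.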